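Swapping 4-methylpiperazin-1-yl for azepan-1-yl in compound 3

A few compounds are considered here, and "the series" means these few. Any claim that something is new, unique, unknown or untested is made for them only; others in the source may bear on it.

In a functional assay on MDA-MB-231 cells (Homo sapiens) for inhibition, read by MTT assay, with stated times of 18 h and 4 h (on this read-out lower numbers stand for stronger inhibition and higher numbers for weaker inhibition), compound 2 (`CCCCCCCCOP(=O)(O)OCCSC(=S)N1CCCCC1`) gives 11900 nM, and compound 3 (`CCCCCCCCOP(=O)(O)OCCSC(=S)N1CCN(C)CC1`) gives 58500 nM, the higher of the two actual numbers. Compound 1 (`CCCCCCCCCCCCCCCCOP(=O)(O)OCCSC(=S)N1CCCCCC1`) reports only a limit, > 100000 nM.

Compound 4 (`CCCCCCCCOP(=O)(O)OCCSC(=S)N1CCCCCC1`) differs from compound 3 at one place, on a thiocarbonyl carbon: azepan-1-yl in place of 4-methylpiperazin-1-yl on a thiocarbonyl carbon. Going by the values given here, one measured step bears on this change. The modest step of a 4.9-fold higher number from compound 2 to compound 3 (0.69 log units; beyond the scatter) brought in the same 4-methylpiperazin-1-yl group with piperidin-1-yl leaving, and compound 4 gives that group up again, so a step of similar size towards lower numbers is expected in this assay. Among the compounds with values here, compound 1 also carries azepan-1-yl, but its chain is different and its limit gives no size of step. Azepan-1-yl itself has not been compared with piperidin-1-yl on the octyl chain, so the range stays wide. The expected change is a 4.2-fold lower number from compound 3 to compound 4 (0.62 log units; beyond the scatter). For compound 4 the estimated value is 14000 nM, with an expected range of 4500 nM to 45000 nM.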

Compound 4, half-maximal inhibitory concentration: 27000 nM
Compound 4: the middle estimate sits 1.9-fold (0.29 log units) below what was measured, within the range that was stated.
By their numbers in this assay, from the lowest: compound 2; then compound 4; then compound 3. At a limit, above all of these: compound 1.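

With the octyl chain held fixed, azepan-1-yl on the thiocarbonyl carbon can now be compared directly with both six-membered rings: a 2.2-fold lower number from compound 3 to compound 4 (0.34 log units; beyond the scatter) and a 2.3-fold higher number from compound 2 to compound 4 (0.36 log units; beyond the scatter). Compound 4 therefore falls on the scale with one six-membered ring on either side of it, so among these three compounds, ring size alone does not set the order. With azepan-1-yl kept in place, the shorter chain of compound 4 also gives an at least 3.7-fold lower number from compound 1 to compound 4 (0.56 log units; beyond the scatter), but compound 1 gives only a limit, so the full size of this step stays unknown: the limit of > 100000 nM in this assay, at which 1 of the 4 values shown sits.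

As far as these compounds go, what a morpholine ring or an open-chain diethylamino group would do on the same carbon remains open. So does the response to chain length, since a dodecyl chain could show how the number changes with intermediate length.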